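The compounds below may be only part of what the source reports. "The series", "measured", "known", "first", "only" and "open" are said of these compounds alone.

The measured compounds and their values in a functional assay on JeKo-1 cells (Homo sapiens) for inhibition, read by luminescence and CellTiter-Glo, with a stated time of 72 h; a lower number here means a stronger inhibitor, a higher number a weaker inhibitor:

Compound 1, `C/C=C/C(=O)Nc1ccc(Cn2nc(-c3ccc(Oc4ccccc4)cc3)cc2C(=O)O)cc1`: > 60000 nM, a limit of the assay.
Compound 2, `O=C(CCl)Nc1ccc(Cn2nc(-c3ccc(Oc4ccccc4)cc3)cc2CO)cc1`: 400 nM.
Compound 3, `C/C=C/C(=O)Nc1ccc(Cn2nc(-c3ccc(Oc4ccccc4)cc3)cc2C(=O)OCC)cc1`: 52500 nM.

Compound 3 stands at the highest of the two numbers in this assay. Compound 2 gives the lower number, and the gap from it to compound 3 is beyond the scatter. Compound 1 gives only a limit, so its place relative to the others cannot be fixed.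

Compound 4, `C/C=C/C(=O)Nc1ccc(Cn2nc(-c3ccc(Oc4ccccc4)cc3)cc2CO)cc1`, differs from compound 3 by hydroxymethyl in place of ethoxycarbonyl on an aromatic carbon. Among the measured compounds shown here, only one measured step touches this part of the core: an at least 1.1-fold lower number from compound 1 to compound 3 (0.05 log units; that floor lies within the scatter). That step, from the acid to the ethyl ester with the same crotonamide, is within the scatter, and compound 1 sits at the limit, so it tells little about how the carbonyl-bearing group governs the number. For the measured compounds named here, compound 2 carries a hydroxymethyl here, as compound 4 will, but its amide differs, so no step separates the two changes.

Given the weak numbers of compound 1 and compound 3, compound 4 is expected to remain well above compound 2, and the step of a 3.5-fold lower number from compound 3 to compound 4 (0.54 log units; beyond the scatter) is estimated to be a modest lowering at most. Compound 4 is therefore estimated at 15000 nM, within 1500 nM to 60000 nM.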

Compound 4, half-maximal inhibitory concentration: > 60000 nM
Compound 4 gave a limit, no number; the forecaster's own chance of this, stated with the estimate: 25%; middle value at least 4.0-fold (0.60 log units) from the limit.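

In this assay, with the prop-1-en-1-yl amide held fixed, hydroxymethyl in place of ethoxycarbonyl on this aromatic carbon gives an at least 1.1-fold higher number from compound 3 to compound 4 (0.05 log units; that floor lies within the scatter), so this change shows no lowering of the number, and any rise beyond that small floor cannot be read. Hydroxymethyl at this position is therefore not enough on its own to give a number like that of compound 2, for with hydroxymethyl held fixed, prop-1-en-1-yl in place of chloromethyl on a carbonyl carbon gives an at least 150-fold higher number from compound 2 to compound 4 (2.17 log units; beyond the scatter), which places the large gap in this pair at the amide end and not on the aromatic carbon. The step between the acid compound 1 and compound 4 cannot be read, since both values are limits and neither is a number: the limit of > 60000 nM in this assay, at which 2 of the 4 values shown sit.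

The compounds shown leave open how far compound 1 and compound 4 lie beyond that limit, and whether the group on this aromatic carbon matters at all with the chloromethyl amide, where only hydroxymethyl appears. They also leave open what an aminomethyl group or a primary carboxamide would do at this position.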